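A few compounds are considered here, and "the series" means these few. Any claim that something is new, unique, unknown or untested is made for them only; others in the source may bear on it.

Of the compounds shown here, three sharing one core have been measured. Compound 1 `NCCCC[C@H](NC(=O)CN(c1nc(Cl)nc2[nH]cnc12)C1CC1)C(=O)OCc1ccccc1`, compound 2 `CC[C@H](C)[C@H](NC(=O)CN(c1nc(Cl)nc2[nH]cnc12)C1CC1)C(=O)OCc1ccccc1` and compound 3 `NC(=O)C[C@H](NC(=O)CN(c1nc(Cl)nc2[nH]cnc12)C1CC1)C(=O)OCc1ccccc1` differ only in the side chain on the carbon bound to an amide-type nitrogen and a carbonyl carbon. In a functional assay on the whole organism (Tail, strain ICR) with Mus musculus as the target, in the tail flick test, with a stated time of 120 min, at a dose of 25 umol/kg by the oral route (on this read-out lower numbers stand for a weaker effect and higher numbers for a stronger effect at the one dose given), compound 1 gives 16.8%, compound 2 gives 22% and compound 3 gives 15.1%. Compound 2 has the largest of the three numbers, but the steps of a number 5.2 percentage points higher from compound 1 to compound 2 (within the scatter) and a number 6.9 percentage points lower from compound 2 to compound 3 (within the scatter) are both within the scatter, as is a number 1.7 percentage points lower from compound 1 to compound 3 (within the scatter), so the three compounds cannot be told apart on these numbers.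

Compound 4 `CC[C@H](C)[C@H](NC(=O)CN(c1nc(Cl)nc2[nH]cnc12)C1CC1)C(=O)O` is compound 2 with the benzyloxycarbonyl group turned into carboxy: hydrogen in place of benzyl on an oxygen next to a carbonyl group. For the measured compounds named here, none of the measured steps touches this oxygen; every one of them changed the side chain instead, and all stayed within the scatter. Going by the values given here, there is therefore no measured step that bears on this change, and no basis for expecting a step beyond the scatter in this assay. The expected step is a number 4 percentage points lower from compound 2 to compound 4 (within the scatter). Compound 4 is estimated at 18%, within a range from 5% to 35%.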

Compound 4, a percentage reported as activity, at one dose (the size of the read-out at that dose, not a potency): 21.4%
Estimate against measurement, compound 4: 3.4 percentage points below; the range from low to high includes it.
By their numbers in this assay, from the lowest: compounds 3, 1, 4 and 2 (each within the scatter of the next).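

For the compounds shown here, this is the first measured change away from the side chain, and it reaches the far end of the molecule: hydrogen in place of benzyl on an oxygen next to a carbonyl group gives a number 0.6 percentage points lower from compound 2 to compound 4 (within the scatter) in this read-out. In this assay the benzyl group can therefore be removed, leaving carboxy in place of benzyloxycarbonyl, without a step that stands out from the scatter. The data offer no explanation for this result.

The carboxy form is shown only with the sec-butyl side chain, so it remains open whether it would behave alike with the 4-aminobutyl or carbamoylmethyl side chains. Also open, going by these compounds, is what a methyl ester or a primary amide in place of the carboxy group would give at this one dose.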